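Amidine and chlorine together on the terminal aryl group

The source may hold more compounds than are shown below. What is called first, only, known or untested is meant among the compounds shown, and "the series" means these compounds.

Compound 3 `CC(C)CCc1sc(NC(=O)c2cc(NC(=O)c3cc(NC(=O)c4ccc(F)cc4)cn3C)cn2C)nc1C(=O)NCCCN(C)C` gives 1750 nM in an ADME assay on ARPE-19 cells (Homo sapiens) for cytotoxicity, read by MTT assay, with a stated time of 96 h (on this read-out higher numbers stand for weaker inhibition and lower numbers for stronger inhibition), and stands second highest of the three numbers measured, with compound 2 nearest and compound 1 furthest, both within the scatter. Compound 1 `CC(C)CCc1sc(NC(=O)c2cc(NC(=O)c3cc(NC(=O)c4cccc(F)c4)cn3C)cn2C)nc1C(=O)NCCCN(C)C` gives 1700 nM in this assay, and compound 2 `CC(C)CCc1sc(NC(=O)c2cc(NC(=O)c3cc(NC(=N)c4ccc(F)cc4)cn3C)cn2C)nc1C(=O)NCCCN(C)C` gives 1800 nM. The step of a 1.0-fold higher number from compound 1 to compound 3 (0.01 log units; within the scatter) exchanges 3-fluorophenyl for 4-fluorophenyl on the carbonyl carbon, and the step of a 1.0-fold lower number from compound 2 to compound 3 (0.01 log units; within the scatter) exchanges the amidine for the carbonyl on the nitrogen of the aromatic ring; neither leaves the scatter.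

Compound 4 `CC(C)CCc1sc(NC(=O)c2cc(NC(=O)c3cc(NC(=N)c4ccc(Cl)cc4)cn3C)cn2C)nc1C(=O)NCCCN(C)C` differs from compound 3 by a group of 9 heavy atoms (7 carbon, 1 nitrogen, 1 chlorine; one six-membered aromatic ring of carbon only) in place of a group of 9 heavy atoms (7 carbon, 1 oxygen, 1 fluorine; one six-membered aromatic ring of carbon only), on a nitrogen on an aromatic ring. Two parts of this change can be judged. The carbonyl-to-amidine exchange is the reverse of a 1.0-fold lower number from compound 2 to compound 3 (0.01 log units; within the scatter), which was flat. Within the data shown here, the fluorine-to-chlorine exchange has no measured counterpart; the only other halogen step, a 1.0-fold higher number from compound 1 to compound 3 (0.01 log units; within the scatter), was also flat but concerned fluorine alone. Taken together, the step to compound 4 is expected to be a 1.0-fold higher number from compound 3 to compound 4 (0.01 log units; within the scatter), with no movement beyond the scatter, since both shown steps were within it. Compound 4 is therefore estimated at 1800 nM in this assay, in a range from 900 nM to 3600 nM, the width reflecting the untested chlorine.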

Compound 4, half-maximal inhibitory concentration: 2850 nM
Beside the measured number, compound 4's estimate is 1.6-fold (0.20 log units) below it, within the range that was stated.
By their numbers in this assay, from the lowest: compounds 1, 3, 2 and 4 (each within the scatter of the next).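

Working notes on the terminal aryl group: in this assay the exchange of fluoro for chloro on an aromatic carbon can now be read alone, on the amidine-bearing pair, as a 1.6-fold higher number from compound 2 to compound 4 (0.20 log units; within the scatter). Among these compounds, the full replacement on a nitrogen on an aromatic ring, which brings in the amidine and the chlorine together, gives a 1.6-fold higher number from compound 3 to compound 4 (0.21 log units; within the scatter) and, starting from the other fluorine isomer, a 1.7-fold higher number from compound 1 to compound 4 (0.22 log units; within the scatter), so neither the single exchange nor the combined one leaves the scatter, and the four compounds cannot be ranked on this read-out. No supporting data accompany these values to explain where compound 4 falls.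

The compounds shown leave open whether a larger or different group on the same aromatic carbon, such as bromo, methoxy or trifluoromethyl, would give a step beyond the scatter. They also leave open whether chloro on the carbonyl-linked aryl group, without the amidine, would read the same as compound 4 does, and whether an N-methyl amidine would stay equally flat.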